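The compounds below may be only part of what the source reports. "The series", "measured", "known", "first", "only" and "open" are said of these compounds alone.

Compound 1, `CCOc1cc(C(=CC#N)c2ccc(S(C)(=O)=O)cc2)ccc1OC`: in a functional assay on HCT-116 cells (Homo sapiens) for cytotoxicity, read by scintillation counting and thymidine incorporation, with a stated time of 72 h (on this read-out higher numbers stand for weaker inhibition and lower numbers for stronger inhibition), compound 1 reaches only the limit of > 10000 nM, a boundary of the test rather than a number.
Compound 2, `CC=C(c1cc(OC)cc(OC)c1)c1ccc(OC)c(OC)c1`: compound 2 gives 480 nM.
Compound 3, `CC=C(c1cc(OC)cc(OC)c1)c1ccc(OC)c(O)c1`: compound 3 gives 30 nM.

Among the measured compounds shown here, of the two compounds with a real number, compound 2 stands at the higher one, so it is the weaker of the two; the single measured step runs a 16-fold lower number from compound 2 to compound 3 (1.20 log units; beyond the scatter), a change on an oxygen of an aromatic ring, and the limit of > 10000 nM in this assay, at which 1 of the 3 values shown sits, belongs to a compound of a different build.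

Compound 4, `C#CC=C(c1cc(OC)cc(OC)c1)c1ccc(OC)c(OC)c1`, differs from compound 2 by ethynyl in place of methyl on a double-bonded chain carbon bound to a double-bonded chain carbon. For the measured compounds named here, no measured step touches this part of the molecule: the one step known, from compound 2 to compound 3, alters an aromatic ring substituent, not the chain carbon that carries the change here. Going by the values given here, nothing among the measured compounds therefore points to a shift in either direction, and the expectation is a step for compound 4 that stays within the scatter, with a wide band around it.

Compound 4 is estimated at 480 nM, between 120 nM and 2000 nM, which means an expected step of no change at the digits printed from compound 2 to compound 4 (within the scatter).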

Compound 4, half-maximal inhibitory concentration: > 10000 nM
Compound 4: a limit, no number; the forecaster's own chance of this, stated with the estimate: 10%; at least 20-fold (1.31 log units) between middle value and limit.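

Among the compounds shown here, replacing the methyl on this double-bonded chain carbon with ethynyl in this assay gives an at least 20-fold higher number from compound 2 to compound 4 (1.31 log units; beyond the scatter), so a change at this place can also produce a large step, here towards weaker inhibition, whereas the only earlier step, a 16-fold lower number from compound 2 to compound 3 (1.20 log units; beyond the scatter), came from a change on an aromatic oxygen and ran towards stronger inhibition. The value of compound 4, > 10000 nM, is a limit of the test and not a number. The step therefore has a minimum size but no exact size, and this limit now recurs within the series: the limit of > 10000 nM in this assay, at which 2 of the 4 values shown sit.

Only one replacement for the methyl on this chain carbon is shown, so it remains open whether an ethyl group, a longer chain or an amine there would also give a large step, or whether the result is particular to ethynyl. Also open is how ethynyl would behave together with the hydroxyl group of compound 3, since no compound shown carries both changes.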